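Carboxyphenoxy repositioning in the thiazepinone pyrazole series

A few compounds are considered here, and "the series" means these few. Any claim that something is new, unique, unknown or untested is made for them only; others in the source may bear on it.

The series shares the core of compound 1 `Cc1ccccc1-n1nc(C)c2c1NC(=O)[C@H](C)S[C@@H]2c1ccc(-c2ccoc2)cc1`, which in an assay on isolated protein for agonist activity at Bile acid receptor (Homo sapiens), read by AlphaScreen, with a stated time of 30 min (a lower number here means that less compound is needed, a higher number that more compound is needed for the effect), gives 3500 nM. Compound 2 `COc1ccc(Oc2ccc([C@H]3S[C@@H](C)C(=O)Nc4c3c(C)nn4-c3ccccc3C)cc2)cc1` carries a 4-methoxyphenoxy in place of the furan-3-yl, and in this assay compound 2 gives 2200 nM; the step of a 1.6-fold lower number from compound 1 to compound 2 (0.20 log units; within the scatter) is within the scatter, so the two aryl ethers and the furan read alike here. Compound 3 `Cc1ccccc1-n1nc(C)c2c1NC(=O)[C@H](C)S[C@@H]2c1ccc(Oc2ccc(C(=O)O)cc2)cc1`, with a 4-carboxyphenoxy at the same position, is recorded in this assay as "not active" (no number reported), with no number given, so compound 3 stands below anything measured for compound 1 or compound 2.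

Compound 4 `Cc1ccccc1-n1nc(C)c2c1NC(=O)[C@H](C)S[C@@H]2c1ccc(Oc2ccccc2C(=O)O)cc1` differs from compound 3 by 2-carboxyphenyl in place of 4-carboxyphenyl on an oxygen on an aromatic ring. Going by the values given here, no measured step bears directly on this change: the only step, from compound 1 to compound 2, concerns a different substituent and is within the scatter. Among the compounds with values here, the sole information on a carboxylic acid at this position is the inactive reading of compound 3, so a number for compound 4 that stays weak is expected, and a further limit-only result is a real possibility.

For compound 4 in this assay, a value of 15000 nM is estimated, expected to fall between 4000 nM and 60000 nM.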

Compound 4, half-maximal effective concentration: "not active" (no number reported)
The entry for compound 4 holds no number; the estimate stays without a comparison.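

In this assay compound 3 gives "not active" (no number reported) and compound 4 gives "not active" (no number reported) so no step can be read between the two. The compounds shown leave open whether 2-carboxyphenyl and 4-carboxyphenyl differ at all in this assay, since neither acid has a number. Nothing measured here bears on these two results.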